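A few compounds are considered here, and "the series" means these few. Any claim that something is new, unique, unknown or untested is made for them only; others in the source may bear on it.

Compound 1 `CC(=O)c1ccc(NC(=O)C(CC(C)C)N(C(=O)c2ccccc2)S(=O)(=O)c2ccc(C)cc2)cc1`: 54%
Compound 2 `CC(=O)c1ccc(NC(=O)C(CC(C)C)N(C(=O)c2ccccc2)S(=O)(=O)c2ccc([N+](=O)[O-])cc2)cc1`: 45%
Compound 3 `CC(=O)c1ccc(NC(=O)CN(C(=O)c2ccccc2)S(=O)(=O)c2ccccc2)cc1`: 40.5%

All three were tested in a functional assay for inhibition, read by spectrophotometry, with a stated time of 20 min, tested at 1 mg/mL; a lower number here means a weaker effect, a higher number a stronger effect of the compound at the concentration tested. Compound 3 gives the lowest of the three numbers: compound 2 stands slightly higher, within the scatter, while compound 1 stands higher by a margin beyond the scatter. Compound 4 `CC(=O)c1ccc(NC(=O)C(CC(C)C)N(C(=O)c2ccccc2)S(=O)(=O)c2ccccc2)cc1` differs from compound 3 by isobutyl in place of hydrogen on a saturated chain carbon bound to an amide-type nitrogen and a carbonyl carbon. Among the measured compounds shown here, no measured step covers this change; the only measured step, a number 9 percentage points lower from compound 1 to compound 2 (within the scatter), concerns a different part of the molecule and stays within the scatter. Compound 1 with 54% and compound 2 with 45% both carry the isobutyl group and lie above compound 3, so a modest rise is expected, a number 8.5 percentage points higher from compound 3 to compound 4 (within the scatter). Compound 4 is therefore estimated at 49%, between 36% and 62%.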

Compound 4, a percentage reported as inhibition, at one concentration (the size of the read-out at that concentration, not a potency): 27.7%
For compound 4 the middle estimate is 21.3 percentage points above the measured one; the whole stated range lies above it.
By their numbers in this assay, from the lowest: compound 4; then compounds 3, 2 and 1 (each within the scatter of the next, the first and the last beyond it).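

In this assay, isobutyl in place of hydrogen on a saturated chain carbon bound to an amide-type nitrogen and a carbonyl carbon does not raise the read-out: it gives a number 12.8 percentage points lower from compound 3 to compound 4 (beyond the scatter). With isobutyl present, the aromatic carbon also proves to matter, since hydrogen in place of nitro gives a number 17.3 percentage points lower from compound 2 to compound 4 (beyond the scatter) and hydrogen in place of methyl gives a number 26.3 percentage points lower from compound 1 to compound 4 (beyond the scatter), whereas methyl and nitro themselves stayed within the scatter of each other. Nothing available explains these drops. On these data alone, whether the isobutyl step runs the same way with methyl or nitro on the aromatic carbon stays open, as does the effect of a benzyl group on that chain carbon or a methoxy group on the aromatic carbon.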